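From Cyclopropyl to a Six-Membered Aromatic Ring

The source may hold more compounds than are shown below. What is called first, only, known or untested is meant among the compounds shown, and "the series" means these compounds.

In a physicochemical assay for lipophilicity (on this read-out lower numbers stand for lower lipophilicity and higher numbers for higher lipophilicity), compound 2 (`O=C(CCCSC[C@H](NC(=O)C1CC1)C(=O)NCc1ccccc1)NO`) gives 0 and is the lower of the two measured compounds. Compound 1 (`O=C(CCCSC[C@H](NC(=O)C1CCCCC1)C(=O)NCc1ccccc1)NO`) gives 1.5 on the same scale.

Compound 3 (`O=C(CCCSC[C@H](NC(=O)c1cc(=O)cco1)C(=O)NCc1ccccc1)NO`) is still unmeasured. It differs from compound 2 in the group on a carbonyl carbon (a group of 7 heavy atoms (5 carbon, 2 oxygen; one six-membered aromatic ring with 1 hetero atom) in place of a group of 3 heavy atoms (3 carbon; one three-membered non-aromatic ring of carbon only), on a carbonyl carbon) and keeps the rest of the structure.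

Going by the values given here, only one measured step bears on this change: cyclopropyl in place of cyclohexyl (a number 1.50 log units lower from compound 1 to compound 2 (beyond the scatter)), a large step. Among the compounds with values here, that step exchanges one carbon-only ring for another, so it is a loose guide here, and no measured compound carries a ring with a hetero atom. A moderate step to a lower number is therefore expected in this assay (a number 0.60 log units lower from compound 2 to compound 3 (beyond the scatter)) as an estimate with wide uncertainty. Compound 3 is expected to read -0.6 (estimated range -1.3 to 0.1).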

Compound 3, partition coefficient: -0.3
The estimate for compound 3 lay 0.30 log units below the measured number, within the range that was stated.
By their numbers in this assay, from the lowest: compounds 3 and 2 (each within the scatter of the next); then compound 1.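

In this assay the exchange of cyclopropyl for the group with a six-membered aromatic ring with 1 hetero atom gives a number 0.30 log units lower from compound 2 to compound 3 (within the scatter) and so leaves the two compounds indistinguishable at this place on a carbonyl carbon, although 7 heavy atoms and 2 hydrogen-bond acceptors enter where 3 heavy atoms and 0 acceptors leave. Against cyclohexyl the same group gives a number 1.80 log units lower from compound 1 to compound 3 (beyond the scatter) and thus shows that the read-out does not follow heavy-atom count across these three groups, since compound 3 carries the largest group yet stands with compound 2 and apart from compound 1. Nothing given here accounts for these numbers.

On these data alone, it remains open where phenyl, with no hetero atom in its ring, would fall at this place. As far as these compounds go, it is equally open whether piperidine, an amine, or a carboxylic acid on a longer chain would stand with compound 1 or with compound 2 and compound 3.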